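Cytotoxicity notes on the amine substituent series

The source may report more compounds than this note shows. Statements on the series, on what has been measured and on what is new or still open speak of the compounds shown alone.

Three measured members share one core. Compound 1 `COc1cc2cc(C#N)ccc2c(OC)c1Oc1cc(NC(C)C)nc(Nc2ccc(C#N)cc2)n1` carries isopropyl on a nitrogen on an aromatic ring; in an ADME assay on MT4 cells (Homo sapiens) for cytotoxicity, read by MTT assay, with a stated time of 5 days (on this read-out higher numbers stand for lower toxicity in this test and lower numbers for higher toxicity in this test), compound 1 gives only a limit of > 125000 nM. Compound 2 `COc1cc2cc(C#N)ccc2c(OC)c1Oc1cc(NCC2CC2)nc(Nc2ccc(C#N)cc2)n1` carries cyclopropylmethyl in that place; in this assay compound 2 likewise gives only a limit of > 125000 nM. Compound 3 `COc1cc2cc(C#N)ccc2c(OC)c1Oc1cc(NC2CCC2)nc(Nc2ccc(C#N)cc2)n1` carries cyclobutyl there; in this assay compound 3 also gives only a limit of > 125000 nM. Compound 3 thus stands where every value shown stands, since (the limit of > 125000 nM in this assay, at which 3 of the 3 values shown sit). The three steps among these compounds are a step that the two limits leave unreadable from compound 1 to compound 2, a step that the two limits leave unreadable from compound 1 to compound 3 and a step that the two limits leave unreadable from compound 2 to compound 3; none of them yields a readable size.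

Compound 4 `COc1cc2cc(C#N)ccc2c(OC)c1Oc1cc(NCC(O)CO)nc(Nc2ccc(C#N)cc2)n1` differs from compound 3 by 2,3-dihydroxypropyl in place of cyclobutyl on a nitrogen on an aromatic ring. Going by the values given here, no measured step covers the entry of 2,3-dihydroxypropyl, so the only guide is that every variation so far on this nitrogen stayed at the limit. For compound 4 the expected step is a number no higher from compound 3 to compound 4 (the limit leaves the size open), that is, no step beyond the scatter is anticipated. In this assay compound 4 is therefore estimated at 125000 nM with a range from 60000 nM to 250000 nM, most probably reported again as a limit.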

Compound 4, half-maximal cytotoxic concentration: 29500 nM
Beside the measured number, compound 4's estimate is 4.2-fold (0.63 log units) above it; measured number outside the range, below it.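

In this assay this nitrogen is no longer a position where every variation stays at one limit: the change to 2,3-dihydroxypropyl gives an at least 4.2-fold lower number from compound 3 to compound 4 (0.62 log units; beyond the scatter), and the same entry gives an at least 4.2-fold lower number from compound 1 to compound 4 (0.62 log units; beyond the scatter). Read one bond further out, with 1,2-dihydroxyethyl in place of cyclopropyl on a saturated chain carbon bound to a nitrogen on an aromatic ring, the change gives an at least 4.2-fold lower number from compound 2 to compound 4 (0.62 log units; beyond the scatter), so toxicity in this test is higher for compound 4 than for any of the three others. Isopropyl, cyclopropylmethyl and cyclobutyl leave no readable difference among themselves, and compound 4, the only member with oxygen in this substituent, is the only one that departs from the shared limit: the limit of > 125000 nM in this assay, at which 3 of the 4 values shown sit.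

As far as these compounds go, the full size of each step stays open, as does whether the hydroxyl groups or the open chain in place of a ring accounts for the lower number, given that both differences enter together. From the compounds shown here alone, how a single hydroxyl group as in 2-hydroxyethyl, a methoxyethyl chain, a terminal amine or a carboxylic acid on this nitrogen would read in this assay also stays open.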